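Swap of the alkyl group on the ring nitrogen

This account rests on a few compounds, and the source may have more. Where it says the series, first, only, none or still open, it means among the compounds named here.

Measured so far:
compound 1 `Cc1ccc(-n2cnc3cc(C(=O)N4CCCCC4)ccc32)cc1` — 19 nM
compound 2 `CC(C)(C)n1cnc2cc(C(=O)N3CCCCC3)ccc21` — 34 nM

Compound 2 holds the highest of the two numbers in an assay on isolated protein for inhibition of 15-hydroxyprostaglandin dehydrogenase [NAD(+)] (Homo sapiens), read by fluorescence, with a stated time of 15 min; on this read-out lower numbers stand for stronger inhibition and higher numbers for weaker inhibition; its nearest neighbour is compound 1, separated by a 1.8-fold higher number from compound 1 to compound 2 (0.25 log units; within the scatter). Compound 3 `CCCCn1cnc2cc(C(=O)N3CCCCC3)ccc21` differs from compound 2 by butyl in place of tert-butyl on an aromatic nitrogen. For the measured compounds named here, the only measured step at this nitrogen, a 1.8-fold higher number from compound 1 to compound 2 (0.25 log units; within the scatter), lay within the scatter, and no step exchanges one alkyl for another. A step within the scatter is therefore expected, a 1.2-fold higher number from compound 2 to compound 3 (0.07 log units; within the scatter). Compound 3 is estimated at 40 nM, with a range of 15 nM to 110 nM.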

Compound 3, half-maximal inhibitory concentration: 68 nM
Beside the measured number, compound 3's estimate is 1.7-fold (0.23 log units) below it; the range from low to high includes it.
By their numbers in this assay, from the lowest: compounds 1, 2 and 3 (each within the scatter of the next, the first and the last beyond it).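

Exchanging one alkyl for another at this nitrogen, with the same atoms joined differently, gives a 2.0-fold higher number from compound 2 to compound 3 (0.30 log units; within the scatter) in this assay and so does not separate butyl from tert-butyl. Butyl in place of 4-methylphenyl gives a 3.6-fold higher number from compound 1 to compound 3 (0.55 log units; beyond the scatter) and is the only modest step at this position that lies beyond the scatter, while tert-butyl against 4-methylphenyl does not. Nothing available accounts for either step.

Still open, on these data alone, is how a cyclohexyl or benzyl group would compare at this nitrogen. A butyl chain ending in an amine or a carboxylic acid is equally untested in the compounds shown.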